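Amide Variation on a Shared Core at the Adenosine A3 Receptor

The source may report more compounds than this note shows. Statements on the series, on what has been measured and on what is new or still open speak of the compounds shown alone.

Compounds measured so far:
compound 1, `O=C(Nc1nc(-c2ccccc2)nc2c1nnn2Cc1ccccc1)c1cccc([N+](=O)[O-])c1`: 4850 nM
compound 2, `O=C(Nc1nc(-c2ccccc2)nc2c1nnn2Cc1ccccc1)C1CCCC1`: 4690 nM

In an assay on CHO cells for displacement of a labelled ligand from adenosine receptor A3 (Homo sapiens), read by scintillation counting (on this read-out lower numbers stand for stronger inhibition and higher numbers for weaker inhibition), compound 1 gives 4850 nM and compound 2 gives 4690 nM. The two numbers sit within the scatter of each other, as the step of a 1.0-fold lower number from compound 1 to compound 2 (0.01 log units; within the scatter) shows, so neither compound can be called the stronger of the pair; compound 2 merely holds the lower of the two numbers. Compound 3, `O=C(Nc1nc(-c2ccccc2)nc2c1nnn2Cc1ccccc1)c1ccc(C(F)(F)F)cc1`, has not yet been measured. It differs from compound 2 by 4-(trifluoromethyl)phenyl in place of cyclopentyl on a carbonyl carbon. For the measured compounds named here, only the step from compound 1 to compound 2 bears on this change, since it also swaps a group on the same carbonyl carbon, and that step was flat. An aromatic ring and a non-aromatic ring gave the same result there, so the return to an aromatic ring is expected to change little: the step of a 1.0-fold lower number from compound 2 to compound 3 (0.02 log units; within the scatter) is expected to stay within the scatter. Compound 3 is therefore estimated at 4500 nM, with a range from 1500 nM to 13000 nM.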

Compound 3, inhibition constant: 4210 nM
The estimate for compound 3 lay 1.1-fold (0.03 log units) above the measured number, and the stated range covers the measured number.
By their numbers in this assay, from the lowest: compounds 3, 2 and 1 (each within the scatter of the next).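

In this assay, the step of a 1.1-fold lower number from compound 2 to compound 3 (0.05 log units; within the scatter) stays within the scatter, and so does the step of a 1.2-fold lower number from compound 1 to compound 3 (0.06 log units; within the scatter). This position on the carbonyl carbon now holds three different groups, 3-nitrophenyl, cyclopentyl and 4-(trifluoromethyl)phenyl, and none of them separates from the others. The flat result now also covers a group with fluorine atoms and more heavy atoms than cyclopentyl, so neither the aromatic ring, nor the size of the group, nor the choice of ring substituent has yet produced a readable difference here.

Going by these compounds, it remains open whether an amine, a carboxylic acid or a longer alkyl chain on this carbonyl carbon would give a step beyond the scatter. The compounds shown also leave open how changes elsewhere on the shared core would read in this assay. No evidence is available to explain why these numbers stay so close.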